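The source may report more compounds than this note shows. Statements on the series, on what has been measured and on what is new or still open speak of the compounds shown alone.

Three measured compounds share one core and differ only in the aryl group on the sulfonyl sulfur. Compound 1 `O=C(NCc1ccc(CNS(=O)(=O)c2ccccc2Cl)cc1)c1cccnc1` carries 2-chlorophenyl there; in an assay on MDA-MB-231 cells for displacement of a labelled ligand from C-X-C chemokine receptor type 4 (Homo sapiens), read by fluorescence and microscopy, with stated times of 10 min and 30 min (a lower number here means that less compound is needed, a higher number that more compound is needed for the effect), compound 1 gives 100 nM. Compound 2 `O=C(NCc1ccc(CNS(=O)(=O)c2ccccc2F)cc1)c1cccnc1` has fluoro in place of chloro on an aromatic carbon, and in this assay compound 2 gives 100 nM, so no change at the digits printed from compound 1 to compound 2 (within the scatter). Compound 3 `O=C(NCc1ccc(CNS(=O)(=O)c2ccc([N+](=O)[O-])cc2)cc1)c1cccnc1` puts 4-nitrophenyl on the sulfonyl sulfur, and in this assay compound 3 gives 100 nM; here no change at the digits printed from compound 1 to compound 3 (within the scatter) and no change at the digits printed from compound 2 to compound 3 (within the scatter). Compound 2 therefore stands level with compounds 1 and 3, with nothing to separate the three.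

Compound 4 `COc1ccccc1C(=O)NCc1ccc(CNS(=O)(=O)c2ccccc2F)cc1` leaves the sulfonyl side of compound 2 untouched and alters the other end of the molecule: 2-methoxyphenyl in place of pyridin-3-yl on a carbonyl carbon. None of the three measured steps concerns the carbonyl carbon; all of them swap the aryl group on the sulfonyl sulfur, and each left the readout unchanged. Among the measured compounds shown here, the data thus offer no direct precedent for the move from pyridin-3-yl to 2-methoxyphenyl, and no direction can be read from them. The expectation for compound 4 is accordingly a value near that of compound 2, with a wide range reflecting the absent precedent. This step is estimated as no change at the digits printed from compound 2 to compound 4 (within the scatter). Compound 4 is expected to give 100 nM, between 30 nM and 400 nM, in this assay.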

Compound 4, effective concentration (reported as EC, without a stated level of effect): 1 nM
Beside the measured number, compound 4's estimate is 100-fold (2.00 log units) above it; the whole stated range lies above it.
By their numbers in this assay, from the lowest: compound 4; then compounds 1, 2 and 3 (each within the scatter of the next).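

In this assay, the carbonyl end of the molecule responds where the sulfonyl end did not: 2-methoxyphenyl in place of pyridin-3-yl on a carbonyl carbon gives a 100-fold lower number from compound 2 to compound 4 (2.00 log units; beyond the scatter). The three swaps on the sulfonyl sulfur had left the number flat, so the earlier compounds gave no sign that it could move at all, and this is the only step shown that lies beyond the scatter. No measurement at hand speaks to what lies behind this step.

The change itself bundles two differences, the loss of the ring nitrogen of pyridin-3-yl and the arrival of the methoxy group, so the compounds shown cannot say which of them carries the step; a plain phenyl or a 2-methylphenyl group on the same carbonyl carbon would begin to separate the two. As far as these compounds go, it also remains open whether 2-methoxyphenyl has the same effect with 2-chlorophenyl or 4-nitrophenyl on the sulfonyl sulfur, and how the number responds to other groups on the carbonyl carbon, such as an ethoxy-substituted phenyl or a carboxylic acid.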